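A few compounds are considered here, and "the series" means these few. Any claim that something is new, unique, unknown or untested is made for them only; others in the source may bear on it.

Of the compounds shown here, three built on a shared sugar-bearing core have been measured in a functional assay on K562 cells (Homo sapiens), read by MTT assay, with a stated time of 72 h; on this read-out lower numbers stand for stronger inhibition and higher numbers for weaker inhibition. Compound 1 `COc1ncnc2c1c(-c1ccsc1)cn2[C@@H]1O[C@H](CO)[C@@H](O)[C@H]1O` carries a thiophen-3-yl group and a methoxy group on its core, and in this assay compound 1 gives 90 nM. Compound 2 `O=c1[nH]cnc2c1c(-c1ccoc1)cn2[C@@H]1O[C@H](CO)[C@@H](O)[C@H]1O` carries a furan-3-yl group and has an oxo group with a ring amide hydrogen on its core; compound 2 gives 12500 nM. Compound 3 `C#Cc1cn([C@@H]2O[C@H](CO)[C@@H](O)[C@H]2O)c2ncnc(C)c12` carries an ethynyl group and a methyl group on its core, and compound 3 gives 6920 nM. Compound 2 thus stands at the highest of the three numbers, although compound 3 lies within the usual scatter of it, while compound 1 is far away beyond the scatter.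

Compound 4 `O=c1[nH]cnc2c1c(-c1ccsc1)cn2[C@@H]1O[C@H](CO)[C@@H](O)[C@H]1O` has not yet been measured. It differs from compound 2 in one place: thiophen-3-yl in place of furan-3-yl on an aromatic carbon. Among the compounds with values here, no measured pair in this set differs in that single place alone, so the size of this step has to be judged from the change itself. Compound 1 and compound 2 differ in two places at once, so their gap cannot be credited to the ring swap alone. The expected step for this change is small, toward a somewhat lower number, and likely not beyond the scatter: a 2.1-fold lower number from compound 2 to compound 4 (0.32 log units; beyond the scatter). Compound 4 is therefore estimated at 6000 nM, with a likely range from 1500 nM to 25000 nM.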

Compound 4, half-maximal inhibitory concentration: > 20000 nM
Compound 4: a limit, no number (the forecaster's own chance of this, stated with the estimate: 10%); middle value at least 3.3-fold (0.52 log units) away from the limit.
By their numbers in this assay, from the lowest: compound 1; then compounds 3 and 2 (each within the scatter of the next). At a limit, above all of these: compound 4.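

In this assay compound 4 gives > 20000 nM, which is a limit of the assay and not a number. Within the data shown here, this is the first comparison in which only the group on this aromatic carbon changes, and it gives an at least 1.6-fold higher number from compound 2 to compound 4 (0.20 log units; that floor lies within the scatter), so thiophen-3-yl in place of furan-3-yl brings no drop in the number on this oxo core, while how far up the true value of compound 4 lies cannot be read: the limit of > 20000 nM in this assay, at which 1 of the 4 values shown sits. Compound 1 carries the same thiophen-3-yl group and differs from compound 4 in one other place, the methoxy group in place of the oxo group with its ring amide hydrogen, and compound 1 gives 90 nM, so thiophen-3-yl alone does not carry a low number.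

On these data alone, whether the swap between furan-3-yl and thiophen-3-yl would read the same on the core of compound 1, with its methoxy group, stays open. So does how an amine or a carboxylic acid on this same aromatic carbon would read in this assay.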